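Inverting two stereocentres: what happens to cell tolerance?

A few compounds are considered here, and "the series" means these few. Any claim that something is new, unique, unknown or untested is made for them only; others in the source may bear on it.

Compound 1 `C[C@@H]1CN(c2nccc3[nH]c(-c4ccc(F)c(F)c4)nc23)C[C@H](C)N1C`: a limit of the assay, > 50000 nM
Compound 2 `Fc1ccc(-c2nc3c(N4CCCN(CC5CC5)CC4)nccc3[nH]2)cc1F`: 17000 nM
Compound 3 `CN1CCN([C@H]2CC[C@@H](Nc3nccc4[nH]c(-c5cc(F)cc(F)c5)nc34)CC2)CC1`: 14000 nM

In an ADME assay on CHO cells (Cricetulus griseus) for cytotoxicity, read by MTT assay (a lower number here means that less compound is tolerated, a higher number that more compound is tolerated), compound 3 gives 14000 nM and compound 2 gives 17000 nM so these two sit within the usual scatter of each other. Compound 1 gives > 50000 nM as a limit of the assay, not a number.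

Compound 4 `CN1CCN([C@H]2CC[C@H](Nc3nccc4[nH]c(-c5cc(F)cc(F)c5)nc34)CC2)CC1` is built from the same atoms and bonds as compound 3 (the two compounds have the same atoms and bonds and differ only in configuration as drawn: 2 of 2 stereo elements differ (all stereocentres are inverted: mirror images); a stereocentre at a saturated ring carbon is drawn s in compound 3 and r in compound 4; a stereocentre at a saturated ring carbon is drawn s in compound 3 and r in compound 4). Among the compounds with values here, no measured pair shows what such an inversion does, so the estimated step of a 1.1-fold higher number from compound 3 to compound 4 (0.03 log units; within the scatter) is expected to stay within the scatter in this assay with no direction favoured. The estimated value for compound 4 is 15000 nM with an expected range from 6000 nM to 40000 nM when it is measured.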

Compound 4, half-maximal cytotoxic concentration in the CHO assay: 11000 nM
The estimate for compound 4 lay 1.4-fold (0.13 log units) above the measured number; low and high end bracket the measured number.
By their numbers in the CHO assay, from the lowest: compounds 4, 3 and 2 (each within the scatter of the next). At a limit, above all of these: compound 1.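

In the CHO assay, compound 3 gives 14000 nM and compound 4 gives 11000 nM. Within the data shown here, in the CHO assay, inverting both stereocentres on the saturated ring gives a 1.3-fold lower number from compound 3 to compound 4 (0.10 log units; within the scatter), the only measured step at this position, so cell tolerance shows no real response to this change of configuration. In a physicochemical assay for solubility, read by HPLC, using the shake flask method, in phosphate buffer, with a stated time of 20 h, at pH 6.5 (on this read-out lower numbers stand for lower solubility and higher numbers for higher solubility), compound 3 gives 200000 nM and compound 4 gives 200000 nM. In the physicochemical assay, the same inversion gives no change at the digits printed from compound 3 to compound 4 (within the scatter). Configuration is the only variable in this comparison, which keeps both readings clean: the fact that compounds 3 and 4 differ only in the configuration as drawn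

The compounds shown leave open whether a carboxylic acid or a longer chain on this saturated ring would move either number beyond the scatter.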